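A few compounds are considered here, and "the series" means these few. Any claim that something is new, unique, unknown or untested is made for them only; others in the source may bear on it.

Compound 1 `O=C(O)c1cc2cc([N+](=O)[O-])ccc2n1CCCc1ccccc1`: 65.5%
Compound 2 `NS(=O)(=O)c1ccc2c(c1)cc(C(=O)O)n2Cc1ccccc1`: 29.3%
Compound 3 `O=C(O)c1cc2cc([N+](=O)[O-])ccc2n1CCCCCc1ccccc1`: 58%

All three were measured in an assay on cells (Oocyte) for inhibition of pannexin-1 (Mus musculus), read by voltage clamp, tested at 50 uM, in the presence of a further agent that is not named here; a higher number here means more inhibition at the concentration tested (going by the name of the read-out), a lower number less inhibition. Compound 3 stands second highest of the three; its nearest neighbour is compound 1, and that gap lies within the scatter, while compound 2 lies far below it, beyond the scatter. Compound 4 `O=C(O)c1cc2cc([N+](=O)[O-])ccc2n1CCCCc1ccccc1` differs from compound 3 by phenyl in place of benzyl on a saturated chain carbon, four bonds along the chain from an aromatic nitrogen. Going by the values given here, the one measured step that bears on this is a change of the same chain, a number 7.5 percentage points lower from compound 1 to compound 3 (within the scatter), which stayed within the scatter; compound 4 carries a chain of a length between those of compound 1 and compound 3. No step beyond the scatter is therefore expected in this assay. Compound 4 is estimated at 61%, with a range from 48% to 74%. The expected step is then a number 3 percentage points higher from compound 3 to compound 4 (within the scatter).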

Compound 4, a percentage reported as inhibition, at one concentration (the size of the read-out at that concentration, not a potency): "not active" (no number reported)
Compound 4 has no reported number here, so the estimate cannot be set against anything.
By their numbers in this assay, from the lowest: compound 2; then compounds 3 and 1 (each within the scatter of the next).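

Going by these compounds alone, compound 4 is reported only as "not active", with no number, so no step from compound 3 to compound 4 can be read. No evidence shown here accounts for that label. From the compounds shown here alone, how chain length affects inhibition across compounds 1, 3 and 4 remains open.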